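The source may report more compounds than this note shows. Statements on the series, on what has been measured and on what is new or still open speak of the compounds shown alone.

In a toxicity assay on HT-29 cells (Homo sapiens) for cytotoxicity (a higher number here means that more compound is tolerated, a lower number that less compound is tolerated), compound 1 `CC(C)CCn1nc(C(=O)N[C@H]2COc3ccccc3N(C)C2=S)nc1Cc1ccccc1` gives > 100000 nM, which is a limit of the assay and not a number. Compound 2 `CN1C(=S)[C@@H](NC(=O)c2nc(Cc3ccccc3)n(C3CCN(C(=O)OC(C)(C)C)CC3)n2)COc2ccccc21` gives > 100000 nM in this assay, and this too is a limit. Compound 2 therefore has no exact value, and the evidence so far comes down to one line: the limit of > 100000 nM in this assay, at which 2 of the 2 values shown sit.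

Compound 3 `CN1C(=S)[C@@H](NC(=O)c2nc(Cc3ccccc3)n(C3CCNCC3)n2)COc2ccccc21` differs from compound 2 by having hydrogen in place of tert-butoxycarbonyl on an amine nitrogen in a ring. Within the data shown here, no measured pair shows what this change does. In this assay, no step beyond the usual scatter is expected. That expectation rests on compound 2, whose > 100000 nM is a limit. The estimated step is a number no higher from compound 2 to compound 3 (the limit leaves the size open). Compound 3 is expected at 100000 nM, with an estimated range from 30000 nM to 100000 nM.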

Compound 3, half-maximal cytotoxic concentration: > 100000 nM
Compound 3: a limit, no number; the forecaster's own chance of this, stated with the estimate: 80%; the middle value lies on the limit itself.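

Compound 3 gives > 100000 nM in this assay, which is a limit and not a number. Among these compounds, the values of compound 1 and compound 2 are limits too, so no step from either to compound 3 can be read. The compounds shown leave open at what concentration each would become toxic to these cells, and whether any of these structural changes alters that: the limit of > 100000 nM in this assay, at which 3 of the 3 values shown sit.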